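Swapping chloro for an aminoalkyl chain on the shared core

A few compounds are considered here, and "the series" means these few. Any claim that something is new, unique, unknown or untested is made for them only; others in the source may bear on it.

Compound 1 `CC(C)COc1ccc2c(Cl)ccnc2c1`: 3190 nM
Compound 2 `CCOc1ccc2c(NCCCN(C)C)ccnc2c1`: 6780 nM
Compound 3 `CCOc1ccc2c(Cl)ccnc2c1`: 3460 nM

In a functional assay on SK-OV-3 cells (Homo sapiens) for cytotoxicity, read by MTT assay, with a stated time of 48 h (a higher number here means a weaker inhibitor, a lower number a stronger inhibitor), compound 3 gives 3460 nM, the second highest of the three numbers, with compound 1 and compound 2 both within the scatter of it. Compound 4 `CCOc1ccc2c(NCCN(C)C)ccnc2c1` differs from compound 3 in one place: (2-(dimethylamino)ethyl)amino in place of chloro on an aromatic carbon. Within the data shown here, the only step between measured compounds, a 1.1-fold higher number from compound 1 to compound 3 (0.04 log units; within the scatter), concerns the ether chain and says nothing about this change. Compound 2, which carries a related amino chain in place of the chloro, gives 6780 nM, a number close to that of compound 3. Compound 4 is therefore expected to give 5500 nM (range 2500 nM to 12000 nM). The expected step, a 1.6-fold higher number from compound 3 to compound 4 (0.20 log units; within the scatter), is estimated to stay near the scatter, leaning to a weaker inhibitor.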

Compound 4, half-maximal inhibitory concentration: 4620 nM
For compound 4 the middle estimate is 1.2-fold (0.08 log units) above the measured one; the range from low to high includes it.
By their numbers in this assay, from the lowest: compounds 1, 3, 4 and 2 (each within the scatter of the next, the first and the last beyond it).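

In this assay, (2-(dimethylamino)ethyl)amino in place of chloro, on the aromatic carbon opposite the ring nitrogen, gives a 1.3-fold higher number from compound 3 to compound 4 (0.13 log units; within the scatter) and so stays within the scatter, even though the entering group is much larger than chloro. On the side chain, dimethylamino in place of (dimethylamino)methyl gives a 1.5-fold lower number from compound 2 to compound 4 (0.17 log units; within the scatter) and also shows no clear effect of this small change in chain length. No evidence here explains why these numbers stay so close. From the compounds shown here alone, whether a primary amine, a carboxylic acid or a much longer chain at this position would shift the number beyond the scatter remains open.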